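Dimethylsulfamoyl for cyclopropylsulfonyl on a tetralin-free sulfonamide

The source may report more compounds than this note shows. Statements on the series, on what has been measured and on what is new or still open speak of the compounds shown alone.

Measured compounds:
compound 1, `O=S(=O)(Nc1cccc2c1CCCC2c1c[nH]cn1)C1CC1`: 2690 nM
compound 2, `CC(c1cccc(NS(C)(=O)=O)c1)c1c[nH]cn1`: 692 nM
compound 3, `CCS(=O)(=O)Nc1cccc(Sc2c[nH]cn2)c1`: < 10000 nM

In an assay on isolated protein for binding affinity to Alpha-1D adrenergic receptor (Rattus norvegicus), read by radioligand binding (on this read-out lower numbers stand for stronger inhibition and higher numbers for weaker inhibition), compound 1 gives 2690 nM, the higher of the two numbers shown. Compound 2 sits nearer, at 692 nM, a gap beyond the scatter. For compound 3 the result of < 10000 nM is a limit of the assay, not a number, as noted in the limit of < 10000 nM in this assay, at which 1 of the 3 values shown sits.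

Compound 4, `CN(C)S(=O)(=O)Nc1cccc2c1CCCC2c1c[nH]cn1`, differs from compound 1 in one place: dimethylamino in place of cyclopropyl on a sulfonyl sulfur. For the measured compounds named here, no step between measured compounds bears on this change, so the expectation rests on compound 1 alone. The step from compound 1 to compound 4 is expected to be small, a 1.0-fold higher number from compound 1 to compound 4 (0.00 log units; within the scatter), with no direction beyond the scatter. Compound 4 is therefore estimated at 2700 nM, between 900 nM and 8000 nM.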

Compound 4, inhibition constant: 1580 nM
For compound 4 the middle estimate is 1.7-fold (0.23 log units) above the measured one; low and high end bracket the measured number.
By their numbers in this assay, from the lowest: compound 2; then compounds 4 and 1 (each within the scatter of the next).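

In this assay, for the compounds shown here, the swap on the sulfonyl sulfur gives a 1.7-fold lower number from compound 1 to compound 4 (0.23 log units; within the scatter) and is the first step read at this position. Compounds 1 and 4 read alike within the scatter, so at this position dimethylamino, with no ring, serves as well as the three-membered ring of cyclopropyl. Nothing measured here speaks to why the two groups read alike.

Going by these compounds, whether a longer chain such as butyl on the sulfonyl sulfur would keep this reading stays open. So does the effect of a phenyl ring or a morpholine there.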